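Aryl Change and Cytotoxicity in HepG2 Cells

The compounds below may be only part of what the source reports. "The series", "measured", "known", "first", "only" and "open" are said of these compounds alone.

Measured so far:
compound 1, `COc1cccc(CNCCCNc2ccnc3cc(-c4ccc(C(C)(C)C)cc4)ccc23)c1O`: 690 nM
compound 2, `COc1cccc(CNCCCNc2ccnc3cc(Cc4ccc(F)cc4)ccc23)c1O`: 4780 nM

Among the measured compounds shown here, in an ADME assay on HepG2 cells (Homo sapiens) for cytotoxicity, read by luminescence, CellTiter-Glo and ATP content, with a stated time of 72 h (a higher number here means that more compound is needed for the effect, a lower number that less compound is needed), compound 1 gives 690 nM and compound 2 gives 4780 nM; the single step is a 6.9-fold higher number from compound 1 to compound 2 (0.84 log units; beyond the scatter). Compound 2 therefore stands highest of the two numbers. Compound 3, `COc1cccc(CNCCCNc2ccnc3cc(-c4ccccc4)ccc23)c1O`, carries phenyl in place of 4-fluorobenzyl on an aromatic carbon. For the measured compounds named here, only the step from compound 1 to compound 2 bears on this change; since phenyl resembles the 4-(tert-butyl)phenyl of compound 1 more than the 4-fluorobenzyl of compound 2, a downward step is expected because of a 6.9-fold higher number from compound 1 to compound 2 (0.84 log units; beyond the scatter), namely a 3.0-fold lower number from compound 2 to compound 3 (0.48 log units; beyond the scatter). Compound 3 is expected to give 1600 nM in this assay, within 500 nM to 5000 nM.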

Compound 3, half-maximal effective concentration: 3210 nM
For compound 3 the middle estimate is 2.0-fold (0.30 log units) below the measured one; low and high end bracket the measured number.
By their numbers in this assay, from the lowest: compound 1; then compounds 3 and 2 (each within the scatter of the next).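

In this assay phenyl in place of 4-fluorobenzyl gives a 1.5-fold lower number from compound 2 to compound 3 (0.17 log units; within the scatter) and so does not separate these two groups on this aromatic carbon. Hydrogen in place of tert-butyl gives a 4.7-fold higher number from compound 1 to compound 3 (0.67 log units; beyond the scatter) and thus ties the lower number of compound 1 to the tert-butyl group, not to the directly attached phenyl alone. Nothing measured here explains this difference. The compounds shown leave open whether a smaller group such as methyl or methoxy in place of tert-butyl would give the same number, and how an amine or a carboxylic acid there would read.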